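This account rests on a few compounds, and the source may have more. Where it says the series, first, only, none or still open, it means among the compounds named here.

Within the data shown here, in a functional assay on K562 cells (Homo sapiens) for cytotoxicity, read by trypan blue exclusion, with a stated time of 96 h (a lower number here means a stronger inhibitor, a higher number a weaker inhibitor), compound 2 `COc1cc(OC)c(/C=C/S(=O)(=O)Cc2ccc(Cl)c(N)c2)c(OC)c1` gives 10 nM, the lower of the two numbers so far, while compound 1 `COc1cc(OC)c(/C=C/S(=O)(=O)Cc2cc(N)ccc2OC)c(OC)c1` gives 7500 nM. Compound 3 `COc1cc(OC)c(/C=C/S(=O)(=O)Cc2ccc(Cl)cc2N)c(OC)c1` carries 2-amino-4-chlorophenyl in place of 3-amino-4-chlorophenyl on a saturated chain carbon bound to a sulfonyl sulfur. Among the measured compounds shown here, the only measured step on that carbon, a 750-fold lower number from compound 1 to compound 2 (2.88 log units; beyond the scatter), was large, so a rearranged ring may matter, though that step also swapped a group. A weaker result is expected, with an estimated 10-fold higher number from compound 2 to compound 3 (1.00 log units; beyond the scatter). The value expected in this assay for compound 3 is 100 nM, within 10 nM to 2000 nM.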

Compound 3, half-maximal inhibitory concentration: 2500 nM
Beside the measured number, compound 3's estimate is 25-fold (1.40 log units) below it; measured number outside the range, above it.
By their numbers in this assay, from the lowest: compound 2; then compound 3; then compound 1.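

In this assay the same atoms, joined differently, give a 250-fold higher number from compound 2 to compound 3 (2.40 log units; beyond the scatter) with 2-amino-4-chlorophenyl in place of 3-amino-4-chlorophenyl, so the arrangement on this ring matters and not only which groups it carries. The same ring gives only a 3.0-fold lower number from compound 1 to compound 3 (0.48 log units; beyond the scatter) when set against 5-amino-2-methoxyphenyl, so a ring with chlorine does not by itself bring the low number of compound 2. Nothing measured here explains this difference.

From the compounds shown here alone, whether the amino group is needed remains open. So does whether bromine or methyl could replace the chlorine of compound 2 and keep its number.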